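Swapping bromo for nitro on a flat series

The source may report more compounds than this note shows. Statements on the series, on what has been measured and on what is new or still open speak of the compounds shown alone.

Compound 1 `O=C1C=CCC/C1=C\C=C\c1ccccc1` at 4500 nM
Compound 2 `O=C1C=CCC/C1=C\C=C\c1ccc(Cl)cc1` at 4800 nM
Compound 3 `O=C1C=CCC/C1=C\C=C\c1ccc(Br)cc1` at 4500 nM

All three were tested in a functional assay on HGC-27 cells (Homo sapiens) for cytotoxicity, read by MTT assay, with a stated time of 72 h (a higher number here means a weaker inhibitor, a lower number a stronger inhibitor), and compound 3 stands level with compound 1 at the digits shown, while compound 2 lies within the scatter of both. The next compound, compound 4 `O=C1C=CCC/C1=C\C=C\c1ccc([N+](=O)[O-])cc1` has nitro in place of bromo on an aromatic carbon, para to a large group nitro in place of bromo on an aromatic carbon and the rest of the structure stays the same.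

For the measured compounds named here, three measured steps bear on this change. Chloro in place of hydrogen gave a 1.1-fold higher number from compound 1 to compound 2 (0.03 log units; within the scatter) and bromo in place of hydrogen gave no change at the digits printed from compound 1 to compound 3 (within the scatter) while bromo in place of chloro gave a 1.1-fold lower number from compound 2 to compound 3 (0.03 log units; within the scatter) so none of these swaps moved the number beyond the scatter. Going by the values given here, no nitro compound has been measured yet, so this flat pattern is only a guide and the range must stay wide. The expected outcome is no change at the digits printed from compound 3 to compound 4 (within the scatter) in this assay with no step beyond the scatter in either direction. Compound 4 is estimated at 4500 nM within an expected range (1800 nM to 10000 nM).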

Compound 4, half-maximal inhibitory concentration: 5200 nM
Compound 4: middle estimate off by 1.2-fold (0.06 log units), on the low side; measured number inside the range.
By their numbers in this assay, from the lowest: compounds 1, 3, 2 and 4 (each within the scatter of the next).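

In this assay nitro on this aromatic carbon, para to a large group, gives a 1.2-fold higher number from compound 3 to compound 4 (0.06 log units; within the scatter) and a 1.1-fold higher number from compound 2 to compound 4 (0.03 log units; within the scatter) and a 1.2-fold higher number from compound 1 to compound 4 (0.06 log units; within the scatter) so no swap among hydrogen, chloro, bromo and nitro has yet stepped beyond the scatter. The earlier compounds shown here only tested single halogen atoms against hydrogen, whereas nitro brings 3 heavy atoms and 2 hydrogen-bond acceptors where bromo has 1 heavy atom and no acceptor. Even this bigger change in what is counted leaves the number within the scatter, and no measurement offered here explains that result.

The compounds shown leave open whether a different kind of group at this position, such as an amine, a carboxylic acid or a longer chain, would move the number beyond the scatter. They also leave open whether a change elsewhere on the shared core would do so.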